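The source may report more compounds than this note shows. Statements on the series, on what has been measured and on what is new or still open speak of the compounds shown alone.

Going by the values given here, only two compounds have been measured so far in a functional assay on OVCAR-8 cells (Homo sapiens) for inhibition, read by sulforhodamine B assay, with a stated time of 72 h; on this read-out higher numbers stand for weaker inhibition and lower numbers for stronger inhibition. Compound 1 (`CC1=CC(=O)C(N(C)C)=CC1=O`) gives 5600 nM and compound 2 (`CC1=C(N(C)C)C(=O)C=CC1=O`) gives 35600 nM, so compound 1 holds the lower number of the two, with a gap beyond the usual scatter. The next compound, compound 3 (`CC1=CC(=O)C(C(C)(C)C)=CC1=O`), carries tert-butyl in place of dimethylamino on a double-bonded ring carbon of the core of compound 1: tert-butyl in place of dimethylamino on a double-bonded ring carbon. Among the compounds with values here, no measured pair shows this change on its own, so the data give no direct guide to its size. In this assay, going by these compounds, the expected outcome is no step beyond the scatter, with either direction still open. The estimated step is a 1.1-fold higher number from compound 1 to compound 3 (0.03 log units; within the scatter). For compound 3 the expected value is 6000 nM, within an estimated range of 2000 nM to 18000 nM.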

Compound 3, half-maximal inhibitory concentration: 13500 nM
Beside the measured number, compound 3's estimate is 2.3-fold (0.35 log units) below it, and the stated range covers the measured number.
By their numbers in this assay, from the lowest: compound 1; then compound 3; then compound 2.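

Going by these compounds alone, replacing dimethylamino with tert-butyl on this double-bonded ring carbon gives a 2.4-fold higher number from compound 1 to compound 3 (0.38 log units; beyond the scatter) in this assay and provides the first single-change step, showing that the number at this position depends on the group it carries. The step is modest, but of these two groups, dimethylamino goes with the lower number and so with the stronger inhibition on this read-out. Nothing available explains why the step runs in this direction.

Going by these compounds, whether the nitrogen of dimethylamino matters remains open, since isopropyl, methoxy or morpholine at this carbon could each separate the entering and leaving groups further. On these data alone, it also remains open whether a primary amine or a longer chain such as n-butyl would keep the number near that of compound 1 or move it towards that of compound 3.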